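Chloro to trifluoromethyl on the shared core

The source may hold more compounds than are shown below. What is called first, only, known or untested is meant among the compounds shown, and "the series" means these compounds.

compound 1 `CC(C)c1ccc(-c2nc(CN3CCCC3)nn2C)cc1` — 1000 nM
compound 2 `Cn1nc(CN2CCCC2)nc1-c1ccc(Cl)cc1` — > 1000 nM

In an assay on membranes from Jurkat cells for displacement of a labelled ligand from Sigma intracellular receptor 2 (Homo sapiens), read by scintillation counting, with a stated time of 1 h (on this read-out lower numbers stand for stronger inhibition and higher numbers for weaker inhibition), compound 1 gives 1000 nM. Compound 2 gives > 1000 nM, which is a limit of the assay and not a number; it sits at the limit of > 1000 nM in this assay, at which 1 of the 2 values shown sits. Among the measured compounds shown here, the single measured step, a number no lower from compound 1 to compound 2 (the limit leaves the size open), is the only comparison available. Compound 3 `Cn1nc(CN2CCCC2)nc1-c1ccc(C(F)(F)F)cc1` carries trifluoromethyl in place of chloro on an aromatic carbon. For the measured compounds named here, no measured step covers this exchange, so the expectation rests on where compound 2 stands at the limit. Compound 3 is expected near 1500 nM, between 500 nM and 5000 nM, a step that the limit leaves unreadable from compound 2 to compound 3 that may again return a limit rather than a number.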

Compound 3, inhibition constant: > 1000 nM
Compound 3: a limit, no number (the forecaster's own chance of this, stated with the estimate: 55%); the middle value does not contradict the limit.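

Compound 3 gives > 1000 nM in this assay, a limit of the assay and not a number. With isopropyl replaced by trifluoromethyl, the result is a number no lower from compound 1 to compound 3 (the limit leaves the size open), and neither step to compound 3 can be read for size. Trifluoromethyl is now the second group on this aromatic carbon, after chloro, to end at the limit: the limit of > 1000 nM in this assay, at which 2 of the 3 values shown sit.

From the compounds shown here alone, how far compound 2 and compound 3 lie from each other stays open. Also open, going by these compounds, is whether a tert-butyl group, a methoxy group or a longer alkyl chain at this position returns a number.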